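From cyclopentyl to 1-(methoxymethyl)ethyl on the aromatic nitrogen

The source may hold more compounds than are shown below. What is called first, only, known or untested is meant among the compounds shown, and "the series" means these compounds.

Of the compounds shown here, two sharing one core have been measured in a functional assay on FaDu cells (Homo sapiens) for cytotoxicity, read by MTT assay, with a stated time of 72 h; on this read-out lower numbers stand for higher toxicity in this test and higher numbers for lower toxicity in this test. In this read-out, compound 1 (`COc1ccc(NC(=O)C(=O)c2cn(CC3CCO3)c3ccccc23)cn1`) gives 686 nM. Compound 2 (`COc1ccc(NC(=O)C(=O)c2cn(C3CCCC3)c3ccccc23)cn1`) gives 370 nM, which lies within the scatter of compound 1, so no order between the two can be claimed. The next compound, compound 3 (`COCC(C)n1cc(C(=O)C(=O)Nc2ccc(OC)nc2)c2ccccc21`), changes only the group on the nitrogen: 1-(methoxymethyl)ethyl in place of cyclopentyl on an aromatic nitrogen. This places 1-(methoxymethyl)ethyl, which has no ring, where compound 2 carries cyclopentyl.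

For the measured compounds named here, one measured step bears on this change: a 1.9-fold lower number from compound 1 to compound 2 (0.27 log units; within the scatter). It involves the same position and the same cyclopentyl, but its other partner, (oxetan-2-yl)methyl, has a ring, so the parallel is only partial. Like the entering group, that partner contains oxygen. Read in reverse, the step hints at a small move towards higher numbers in this assay, though a single step within the scatter sets no pattern. The expected step is a 1.4-fold higher number from compound 2 to compound 3 (0.15 log units; within the scatter), and no change beyond the scatter is expected. For compound 3 the estimated value is 520 nM, with an expected range from 220 nM to 1200 nM.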

Compound 3, concentration lethal to 50% of the cells: 12 nM
Compound 3: the middle estimate sits 43-fold (1.64 log units) above what was measured; the measured number lies below the stated range.
By their numbers in this assay, from the lowest: compound 3; then compounds 2 and 1 (each within the scatter of the next).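

In this assay, for the compounds shown here, the group on the aromatic nitrogen now proves able to move the number strongly: a 31-fold lower number from compound 2 to compound 3 (1.49 log units; beyond the scatter), and a 57-fold lower number from compound 1 to compound 3 (1.76 log units; beyond the scatter), whereas the only earlier step at this position, a 1.9-fold lower number from compound 1 to compound 2 (0.27 log units; within the scatter), gave no sign of this. Oxygen in the group does not by itself go with the low number, since compound 1 also carries oxygen in its (oxetan-2-yl)methyl group yet lies within the scatter of compound 2, whose cyclopentyl has none; of the three groups, only 1-(methoxymethyl)ethyl in compound 3 has no ring, though one compound sets no pattern. Nothing available explains the size of this drop.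

Still open, from the compounds shown here alone, is which feature of 1-(methoxymethyl)ethyl goes with the low number: its lack of a ring, its methoxy oxygen or its branched carbon. Going by these compounds, a 2-methoxyethyl group, which lacks the branch, and an isopropyl group, which lacks the oxygen, would help to separate these, and it also remains open whether an amine or a longer ether chain at this position would keep the number this low.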